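The compounds below may be only part of what the source reports. "The series", "measured", "known", "first", "only" and "open" are said of these compounds alone.

Measured so far in an ADME assay on a cell-free system (plasma, Homo sapiens) for metabolic stability, read by LC-MS; on this read-out higher numbers stand for a longer-lived compound and lower numbers for a shorter-lived compound:
- compound 1 `CCCCCCOC(=O)c1cccc(-c2cc(C(=O)Nc3ccncc3)ccc2CN)c1`: 0.833 h
- compound 2 `NCc1ccc(C(=O)Nc2ccncc2)cc1-c1cccc(C(=O)OCc2ccccc2)c1`: 1.07 h
- compound 3 `CCCCCOC(=O)c1cccc(-c2cc(C(=O)Nc3ccncc3)ccc2CN)c1`: 0.967 h

Compound 3 stands level with the other two, as both of its steps lie within the scatter: a 1.2-fold higher number from compound 1 to compound 3 (0.06 log units; within the scatter) and a 1.1-fold lower number from compound 2 to compound 3 (0.04 log units; within the scatter). Compound 4 `CCOC(=O)c1cccc(-c2cc(C(=O)Nc3ccncc3)ccc2CN)c1` is not yet measured, and in it pentyl becomes ethyl (hydrogen in place of propyl on a saturated chain carbon, two bonds along the chain from an oxygen next to a carbonyl group). Among the measured compounds shown here, the closest precedent is the hexyl to pentyl step above, while a 1.3-fold higher number from compound 1 to compound 2 (0.11 log units; within the scatter) also stays within the scatter. For the measured compounds named here, no measured compound carries so short a chain, so this reading remains loose. The expected step is a 1.2-fold higher number from compound 3 to compound 4 (0.08 log units; within the scatter), with no change beyond the scatter anticipated. For compound 4 the estimated half-life is 1.15 h, with an expected range of 0.6 h to 2.2 h.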

Compound 4, half-life: 0.683 h
Compound 4: middle estimate off by 1.7-fold (0.23 log units), on the high side; the range from low to high includes it.
By their numbers in this assay, from the lowest: compounds 4, 1, 3 and 2 (each within the scatter of the next).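

Cutting pentyl to ethyl, the shortest chain shown at this position, does not take the half-life in this assay beyond the scatter: a 1.4-fold lower number from compound 3 to compound 4 (0.15 log units; within the scatter). The wider comparisons stay within it too, with a 1.2-fold lower number from compound 1 to compound 4 (0.09 log units; within the scatter) and a 1.6-fold lower number from compound 2 to compound 4 (0.19 log units; within the scatter), so neither the ethyl, pentyl and hexyl chains nor the phenyl group of compound 2 separate at this position. No measured evidence bears on why the numbers fall as they do. From the compounds shown here alone, it remains open whether a carboxylic acid, an amide or a chain carrying an amine at this position would give a step beyond the scatter.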